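A Sulfonamide Added to the Sulfoxide Phenyl of Compound 1

The compounds below may be only part of what the source reports. "The series", "measured", "known", "first", "only" and "open" are said of these compounds alone.

For the measured compounds named here, compound 1 `COc1ccc(CCCCCCCCOc2ccc(C[S+]([O-])c3ccccc3)nc2/C=C/C(=O)O)cc1` gives the lower of two numbers so far measured in an assay for binding affinity to leukotriene B4 receptor 1 (Homo sapiens); a lower number here means a stronger inhibitor, a higher number a weaker inhibitor: compound 1 gives 37 nM, while compound 2 `CCCCCCCCCCCCOc1ccc(C[S+]([O-])c2cccc(C(=O)O)c2)nc1/C=C/C(=O)O` gives 129 nM, a gap that lies beyond the usual scatter of the measurement. Compound 3 `COc1ccc(CCCCCCCCOc2ccc(C[S+]([O-])c3cccc(NS(=O)(=O)c4ccccc4)c3)nc2/C=C/C(=O)O)cc1` has not yet been measured. It differs from compound 1 at a single point: (phenylsulfonyl)amino in place of hydrogen on an aromatic carbon of a six-membered aromatic ring of carbon only, meta to a large group. Going by the values given here, no measured pair shows this exact change, so the size of the step can only be estimated, and compound 2 differs from compound 1 in more than one place, so its value does not isolate it. Compound 3 is expected to give 25 nM, within a plausible range from 8 nM to 100 nM. The step of a 1.5-fold lower number from compound 1 to compound 3 (0.17 log units; within the scatter) is accordingly expected to be small, at most a modest move toward a lower number, and possibly none beyond the scatter.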

Compound 3, inhibition constant: 147 nM
Compound 3: the middle estimate sits 5.9-fold (0.77 log units) below what was measured; the measured number lies above the stated range.
By their numbers in this assay, from the lowest: compound 1; then compounds 2 and 3 (each within the scatter of the next).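

In this assay, the change at this position gives a 4.0-fold higher number from compound 1 to compound 3 (0.60 log units; beyond the scatter), so the sulfoxide phenyl of compound 1 does not take (phenylsulfonyl)amino, meta to a large group, without a rise in the number. The earlier compounds shown here could not show this, since they differ in more than one place and held no step isolating a single group on this ring. No measurement available bears on why the number rises.

As far as these compounds go, it remains open whether a smaller group on the same aromatic carbon, such as an amine or a carboxylic acid, would keep the number of compound 1. Also open, from the compounds shown here alone, is whether the rise follows the sulfonyl, the added phenyl ring or the amino nitrogen, and whether (phenylsulfonyl)amino would give the same step on another carbon of this ring.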